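This account rests on a few compounds, and the source may have more. Where it says the series, first, only, none or still open, it means among the compounds named here.

Compound 1 `Cc1nc(-c2cccnc2)sc1-c1nnc(Cc2ccccc2)o1` gives > 100 ug/mL
Compound 2 `Cc1nc(-c2cccnc2)sc1-c1nnc(-c2ccc(Br)cc2)o1` gives > 100 ug/mL
Compound 3 `Cc1nc(-c2cccnc2)sc1-c1nnc(-c2ccc([N+](=O)[O-])cc2)o1` gives > 100 ug/mL

In an ADME assay on PANC-1 cells (Homo sapiens) for cytotoxicity, read by MTT assay (a higher number here means that more compound is tolerated, a lower number that less compound is tolerated), compound 3 stands at > 100 ug/mL which is a limit of the assay and not a number. Compound 3 is not alone at this limit (the limit of > 100 ug/mL in this assay, at which 3 of the 3 values shown sit). Compound 4 `Cc1nc(-c2cccnc2)sc1-c1nnc(-c2ccccc2)o1` carries hydrogen in place of nitro on an aromatic carbon. For the measured compounds named here, two measured steps bear on this change (a step that the two limits leave unreadable from compound 1 to compound 2) and (a step that the two limits leave unreadable from compound 2 to compound 3), and the second also involves the nitro group. Neither step has a readable size, so neither offers a direction for this assay to follow. The expectation therefore rests on compound 3 at > 100 ug/mL which is again only a limit. No step beyond the usual scatter is expected, and the estimated step is modest (a step that the limit leaves unreadable from compound 3 to compound 4). For compound 4 the expected value is 130 ug/mL with an estimated range from 80 ug/mL to 300 ug/mL and a report as a limit is the likeliest outcome.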

Compound 4, half-maximal cytotoxic concentration: > 100 ug/mL
Compound 4 ended at the assay's limit; the forecaster's own chance of this, stated with the estimate: 85%; the middle value lies beyond the limit too.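

In this assay compound 4 gives > 100 ug/mL, which is a limit of the assay and not a number. No step from compound 1, compound 2 or compound 3 to compound 4 can be read: the limit of > 100 ug/mL in this assay, at which 4 of the 4 values shown sit.

The compounds shown leave open where any of them would reach its half-maximal cytotoxic concentration, and whether the groups that differ on the shared core change it.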